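The source may hold more compounds than are shown below. What is called first, only, known or untested is meant among the compounds shown, and "the series" means these compounds.

Three compounds have so far been measured in a physicochemical assay for solubility, in phosphate buffer, at pH 6.5; on this read-out lower numbers stand for lower solubility and higher numbers for higher solubility:

compound 1 `CNc1nc(NCCCN(C)C)c2sc(-c3ccc(C(F)(F)F)cc3)cc2n1` gives 177 ug/mL
compound 2 `CNc1nc(NCCN2CCNCC2)c2sc(-c3ccc(C(F)(F)F)cc3)cc2n1` gives 115 ug/mL
compound 3 `CNc1nc(NC(C)(C)C)c2sc(-c3ccc(C(F)(F)F)cc3)cc2n1` gives only a limit of the assay, < 1.6 ug/mL

Compound 2 stands close to compound 1, as the step of a 1.5-fold lower number from compound 1 to compound 2 (0.19 log units; within the scatter) shows; the figure for compound 3 is not a number but a limit (the limit of < 1.6 ug/mL in this assay, at which 1 of the 3 values shown sits). The change to compound 4 `CNc1nc(NC2CCOCC2)c2sc(-c3ccc(C(F)(F)F)cc3)cc2n1` is oxan-4-yl in place of 2-(piperazin-1-yl)ethyl on a nitrogen on an aromatic ring. Among the compounds with values here, two measured steps bear on this move, each replacing a chain on that same ring nitrogen with a compact group: an at least 71-fold lower number from compound 2 to compound 3 (1.85 log units; beyond the scatter) and an at least 110-fold lower number from compound 1 to compound 3 (2.04 log units; beyond the scatter). Both were large and pointed the same way, so a large fall in this assay is expected here as well, though the group entering in compound 4 keeps one oxygen, and the fall may stop short of the limit. Compound 4 is therefore expected to give 8 ug/mL (range 1.6 ug/mL to 40 ug/mL), an expected step of a 14-fold lower number from compound 2 to compound 4 (1.16 log units; beyond the scatter).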

Compound 4, solubility: < 5 ug/mL
Compound 4: no number, only a limit (the forecaster's own chance of this, stated with the estimate: 30%); at least 1.6-fold (0.20 log units) between middle value and limit.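

In this assay compound 4 gives < 5 ug/mL, which is a limit and not a number. Putting oxan-4-yl on the nitrogen in place of either amine-bearing chain still gives an at least 23-fold lower number from compound 2 to compound 4 (1.36 log units; beyond the scatter) and an at least 35-fold lower number from compound 1 to compound 4 (1.54 log units; beyond the scatter), so the single oxygen in this ring does not keep the value near those of the two chains. Compound 3 and compound 4 both stand as limits, so the step between them cannot be read and the two groups cannot be ranked.

Still open, going by these compounds, is whether the amine nitrogen or the chain itself goes with the higher values, which a 2-(morpholin-4-yl)ethyl chain or a plain butyl chain on the same nitrogen could help separate. A compact ring holding an amine, such as piperidin-4-yl, could show whether a chain is needed at all.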